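This account rests on a few compounds, and the source may have more. Where it says the series, first, only, none or still open, it means among the compounds named here.

Measured so far:
compound 1, `Cc1ccccc1C(=O)n1c(-c2cn(-c3ccccc3)nc2-c2ccc(F)cc2)nc2ccccc21`: 189000 nM
compound 2, `Cc1ccc(C(=O)n2c(-c3cn(-c4ccccc4)nc3-c3ccc(F)cc3)nc3ccccc32)cn1`: 137000 nM
compound 3, `Cc1ccc(C(=O)n2c(-c3cn(-c4ccccc4)nc3-c3ccc(C(F)(F)F)cc3)nc3ccccc32)cn1`: 153000 nM

All three were tested in an ADME assay on HEK-293T cells (Homo sapiens) for cytotoxicity, read by MTT assay, with a stated time of 24 h; a lower number here means that less compound is tolerated, a higher number that more compound is tolerated. Compound 2 and compound 1 differ in one place, (2-methylphenyl in place of 6-methylpyridin-3-yl on a carbonyl carbon), and that change gave a 1.4-fold higher number from compound 2 to compound 1 (0.14 log units; within the scatter). Compound 2 and compound 3 differ elsewhere, (trifluoromethyl in place of fluoro on an aromatic carbon), and that change gave a 1.1-fold higher number from compound 2 to compound 3 (0.05 log units; within the scatter). Nothing here separates the three numbers from one another beyond the usual scatter.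

Compound 4, `Cc1ccccc1C(=O)n1c(-c2cn(-c3ccccc3)nc2-c2ccc(C(F)(F)F)cc2)nc2ccccc21`, has not yet been measured. It differs from compound 3 by 2-methylphenyl in place of 6-methylpyridin-3-yl on a carbonyl carbon, the same change that leads from compound 2 to compound 1, at the same place in the molecule, in words that match exactly. Because the earlier step was a 1.4-fold higher number from compound 2 to compound 1 (0.14 log units; within the scatter), compound 4 is expected to sit close to compound 3, and the step is estimated as a 1.3-fold higher number from compound 3 to compound 4 (0.12 log units; within the scatter). Two cores that differ by trifluoromethyl in place of fluoro on an aromatic carbon showed no separation earlier, so that difference gives no reason to expect a different outcome. In this assay compound 4 is therefore estimated at 200000 nM, with a range from 120000 nM to 330000 nM.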

Compound 4, half-maximal cytotoxic concentration: 179000 nM
The estimate for compound 4 lay 1.1-fold (0.05 log units) above the measured number, and the stated range covers the measured number.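

In this assay, 2-methylphenyl in place of 6-methylpyridin-3-yl on the carbonyl carbon gave a 1.2-fold higher number from compound 3 to compound 4 (0.07 log units; within the scatter), and this agrees with the same change on the other core: the same change on two cores in this assay, a 1.4-fold higher number (0.14 log units; within the scatter) from compound 2 to compound 1 and a 1.2-fold higher number (0.07 log units; within the scatter) from compound 3 to compound 4, 1.2-fold (0.07 log units) apart, within the scatter of two such steps. Trifluoromethyl in place of fluoro gave a 1.1-fold lower number from compound 1 to compound 4 (0.02 log units; within the scatter), and this also agrees with its earlier counterpart: the same change on two cores in this assay, a 1.1-fold higher number (0.05 log units; within the scatter) from compound 2 to compound 3 and a 1.1-fold lower number (0.02 log units; within the scatter) from compound 1 to compound 4, 1.2-fold (0.07 log units) apart, within the scatter of two such steps. Across these four compounds, then, each change looks the same on both cores, but every step lies within the scatter, so this shows only that neither change moved the number measurably here, not that a real effect of either change carries from core to core.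

All four compounds carry either fluoro or trifluoromethyl on the aromatic ring and a methyl-bearing aromatic ring on the carbonyl, so they cannot show whether a similar agreement would hold for other groups. As far as these compounds go, an amine or a carboxylic acid in place of fluoro, or a longer chain in place of the methyl, remains open, and either might give a step large enough to stand clear of the scatter.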